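The source may hold more compounds than are shown below. What is called first, only, known or untested is meant among the compounds shown, and "the series" means these compounds.

Measured so far:
- compound 1 `CN1[C@@H]2c3[nH]c4ccccc4c3C[C@H]1[C@H](C#N)N1[C@@H](CNC(=O)c3ccc(F)cc3)c3[nH]c4ccccc4c3C[C@@H]21`, 250 nM
- compound 2 `CN1[C@@H]2c3[nH]c4ccccc4c3C[C@H]1[C@H](C#N)N1[C@@H](CNC(=O)c3cc4ccccc4s3)c3[nH]c4ccccc4c3C[C@@H]21`, 20 nM

In a functional assay on A2780 cells (Homo sapiens) for cytotoxicity, read by MTT assay, with a stated time of 72 h (a lower number here means a stronger inhibitor, a higher number a weaker inhibitor), compound 2 holds the lowest number of the two. For the measured compounds named here, the one measured step, a 13-fold lower number from compound 1 to compound 2 (1.10 log units; beyond the scatter), shows that the group on the carbonyl carbon moves the number strongly. Compound 3 `CN1[C@@H]2c3[nH]c4ccccc4c3C[C@H]1[C@H](C#N)N1[C@@H](CNC(=O)/C=C/c3ccccc3)c3[nH]c4ccccc4c3C[C@@H]21` differs from compound 2 by 2-phenylethenyl in place of 1-benzothiophen-2-yl on a carbonyl carbon. Going by the values given here, no measured step covers this exchange; only the step from compound 1 to compound 2 bears on it, and the 2-phenylethenyl group stands between the two measured groups in size and ring count. A moderate rise is therefore expected, a 4.0-fold higher number from compound 2 to compound 3 (0.60 log units; beyond the scatter). Compound 3 is estimated at 80 nM, with a range of 25 nM to 300 nM.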

Compound 3, half-maximal inhibitory concentration: 770 nM
Beside the measured number, compound 3's estimate is 9.6-fold (0.98 log units) below it; measured number above the stated range.
By their numbers in this assay, from the lowest: compound 2; then compound 1; then compound 3.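

In this assay, 2-phenylethenyl on the carbonyl carbon gives a 39-fold higher number from compound 2 to compound 3 (1.59 log units; beyond the scatter) and also a 3.1-fold higher number from compound 1 to compound 3 (0.49 log units; beyond the scatter), so it has the highest number of the three groups. The two groups with a single aromatic ring, in compound 1 and compound 3, both lie well above the 1-benzothiophen-2-yl group, yet they remain separated beyond the scatter. Nothing available explains these differences. Still open, as far as these compounds go, are the separate contributions of the double bond and the sulfur; a saturated 2-phenylethyl chain or a naphthalen-2-yl group would address them.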